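The source may hold more compounds than are shown below. What is called first, only, known or untested is meant among the compounds shown, and "the series" means these compounds.

Three compounds have so far been measured in an assay (strain CD) for inhibition of 3-hydroxy-3-methylglutaryl-coenzyme A reductase (Rattus norvegicus), read by scintillation counting, using microsomes, with a stated time of 90 min; a higher number here means a weaker inhibitor, a lower number a stronger inhibitor:

Compound 1, `CC(CCc1ccc(-c2ccccc2)cc1)CC(=O)O`, gives 80000 nM in this assay.
Compound 2, `CC(CC(=O)O)CC(=O)c1ccc(Oc2ccccc2)cc1`, gives 2100000 nM in this assay.
Compound 3, `CC(CCc1ccc(Oc2ccccc2)cc1)CC(=O)O`, gives 80000 nM in this assay.

Compound 3 stands level with compound 1 at the digits shown, and the two together hold the lowest numbers of the three. For the measured compounds named here, the value of compound 2 lies beyond the scatter from that of compound 3, compound 2 giving the higher number; no single-point step links these two, so only their two values can be set side by side.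

Compound 4, `CC(CCc1ccc(Sc2ccccc2)cc1)CC(=O)O`, is not yet measured. It differs from compound 3 in one place: phenylsulfanyl in place of phenoxy on an aromatic carbon. Going by the values given here, the only measured step that touches the same aromatic carbon is no change at the digits printed from compound 1 to compound 3 (within the scatter), which showed no change beyond the scatter. On that basis the step from compound 3 to compound 4 is expected to be small, no change at the digits printed from compound 3 to compound 4 (within the scatter), with no direction beyond the scatter. Compound 4 is therefore estimated to give about 80000 nM, within a range from 30000 nM to 220000 nM.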

Compound 4, half-maximal inhibitory concentration: 100000 nM
Compound 4: the middle estimate sits 1.3-fold (0.10 log units) below what was measured; the measured number falls inside the stated range.
By their numbers in this assay, from the lowest: compounds 1, 3 and 4 (each within the scatter of the next); then compound 2.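

In this assay, exchanging the oxygen of phenoxy for the sulfur of phenylsulfanyl, on the aromatic carbon para to a group of 8 heavy atoms, gives a 1.3-fold higher number from compound 3 to compound 4 (0.10 log units; within the scatter), and the comparison with the directly attached phenyl gives a 1.3-fold higher number from compound 1 to compound 4 (0.10 log units; within the scatter). Both steps lie within the scatter, so this position has now carried three groups, phenyl, phenoxy and phenylsulfanyl, without a step beyond the scatter among compounds 1, 3 and 4, and the atom linking the outer ring, whether oxygen or sulfur, has not shifted the number. Nothing available explains this insensitivity.

From the compounds shown here alone, all three groups carry the same six-membered aromatic ring of carbon only, so what remains open is whether a group without that ring, such as methyl or a carboxylic acid, would be tolerated here. Also open, going by these compounds, is whether an amine link or a longer chain between the two rings would leave the number in the same place.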